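The source may hold more compounds than are shown below. What is called first, only, known or untested is meant among the compounds shown, and "the series" means these compounds.

Of the compounds shown here, three of a shared core have been measured in a functional assay on CHO-K1 cells for antagonist activity at transient receptor potential cation channel subfamily V member 1 (Homo sapiens), read by FLIPR; on this read-out higher numbers stand for weaker inhibition and lower numbers for stronger inhibition. Compound 1, with the structure `CC(C(=O)NCc1ccc(C(F)(F)F)nc1NCC1CCN(C(=O)OC(C)(C)C)CC1)c1ccc(NS(C)(=O)=O)c(F)c1`, gives 1140 nM. Compound 2, with the structure `CC(C(=O)NCc1ccc(C(F)(F)F)nc1NCc1ccccc1)c1ccc(NS(C)(=O)=O)c(F)c1`, gives 203 nM. Compound 3, with the structure `C[C@H](C(=O)NCc1ccc(C(F)(F)F)nc1N1CC[C@@H](OCc2ccccc2)C1)c1ccc(NS(C)(=O)=O)c(F)c1`, gives 50 nM. On these numbers compound 2 stands second highest of the three: compound 3 lies nearest to it, with a number lower by an amount beyond the scatter, while compound 1 lies furthest from it, with a number higher by an amount beyond the scatter.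

The step under consideration leads from compound 2 to compound 4, whose structure is `CC(C(=O)NCc1ccc(C(F)(F)F)nc1N1CCC(C)(C)CC1)c1ccc(NS(C)(=O)=O)c(F)c1`. The change is 4,4-dimethylpiperidin-1-yl in place of benzylamino on an aromatic carbon. For the measured compounds named here, no measured pair shows exactly this change. Compound 3, which also carries a ring nitrogen bound directly to that aromatic carbon, gives 50 nM, a lower number than compound 2. On that basis a modest step toward stronger inhibition is expected, of a size that may just exceed the scatter, as a 1.8-fold lower number from compound 2 to compound 4 (0.27 log units; within the scatter). Compound 4 is therefore estimated at 110 nM in this assay, within a range from 35 nM to 400 nM.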

Compound 4, half-maximal inhibitory concentration: 8 nM
Beside the measured number, compound 4's estimate is 14-fold (1.14 log units) above it; the whole stated range lies above it.
By their numbers in this assay, from the lowest: compound 4; then compound 3; then compound 2; then compound 1.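

In this assay, placing 4,4-dimethylpiperidin-1-yl in place of benzylamino on this aromatic carbon, next to the ring nitrogen, gives a 25-fold lower number from compound 2 to compound 4 (1.40 log units; beyond the scatter), a large step beyond the scatter. The leaving and entering groups have the same count of heavy atoms, carbon and nitrogen alike, so this position responds strongly to the form of the group even when that count does not change: a six-membered non-aromatic ring with its nitrogen bound directly to the aromatic carbon replaces a benzylamino group with its six-membered aromatic ring of carbon only, and the hydrogen-bond donor of benzylamino is gone. Nothing available here gives a reason for the size of this step.

The single step changes the ring type and the hydrogen-bond donor count together, so the compounds shown cannot say which of these differences goes with the lower number. From the compounds shown here alone, it also remains open how plain piperidin-1-yl, without the two methyl groups, or N-methylbenzylamino, which keeps the benzyl group but has no amine hydrogen, would compare at this position on the same core.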